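Extending a Fluorinated Series With a Nitro Group

A few compounds are considered here, and "the series" means these few. Any claim that something is new, unique, unknown or untested is made for them only; others in the source may bear on it.

Three compounds share one core and differ at a single aromatic carbon. In a functional assay on B16-F10 cells (Mus musculus) for antiproliferative activity, read by ELISA and MTT assay, with a stated time of 48 h (on this read-out lower numbers stand for stronger inhibition and higher numbers for weaker inhibition), compound 1 `Cc1ccc(S(=O)(=O)NC(=O)/C=C/c2ccccc2)cc1` gives 13.8 ug/mL. Compound 2 `O=C(/C=C/c1ccccc1)NS(=O)(=O)c1ccc(F)cc1` gives 2.1 ug/mL in this assay, and compound 3 `O=C(/C=C/c1ccccc1)NS(=O)(=O)c1ccc(Cl)cc1` gives 2.2 ug/mL. The steps are a 6.6-fold lower number from compound 1 to compound 2 (0.82 log units; beyond the scatter), a 6.3-fold lower number from compound 1 to compound 3 (0.80 log units; beyond the scatter) and a 1.0-fold higher number from compound 2 to compound 3 (0.02 log units; within the scatter), so compound 2 stands clearly below compound 1 and within the scatter of compound 3.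

Compound 4 `O=C(/C=C/c1ccc([N+](=O)[O-])cc1)NS(=O)(=O)c1ccc(F)cc1` differs from compound 2 by nitro in place of hydrogen on an aromatic carbon. Within the data shown here, none of the measured steps touches that ring; all three concern the other aromatic carbon, so no direction can be drawn from them. The expected step is therefore no change at the digits printed from compound 2 to compound 4 (within the scatter), within the scatter. Compound 4 is estimated at 2.1 ug/mL, ranging from 0.7 ug/mL to 6.5 ug/mL.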

Compound 4, half-maximal inhibitory concentration: 2.2 ug/mL
Estimate against measurement, compound 4: 1.0-fold (0.02 log units) below, and the stated range covers the measured number.
By their numbers in this assay, from the lowest: compounds 2, 3 and 4 (each within the scatter of the next); then compound 1.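

Among these compounds, the earlier steps all concerned a different aromatic carbon, so this is the first reading at this position. In this assay, nitro in place of hydrogen, para to a large group, gives a 1.0-fold higher number from compound 2 to compound 4 (0.02 log units; within the scatter), so the position carries nitro with the number level with that of compound 2. Nothing available accounts for this outcome. On these data alone, whether an amine or a carboxylic acid on this carbon would also keep the number level stays open. So does whether nitro would give the same result in compound 1 or compound 3.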